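The source may hold more compounds than are shown below. What is called first, only, known or untested is meant among the compounds shown, and "the series" means these compounds.

Measured so far in a functional assay on HepG2 cells (Homo sapiens) for cytotoxicity, read by MTT assay, with a stated time of 72 h; a higher number here means a weaker inhibitor, a lower number a stronger inhibitor:
- compound 1, `CN1[C@@H]2c3[nH]c4ccccc4c3C[C@H]1[C@H](C#N)N1[C@@H](CN3C(=O)c4ccccc4C3=O)c3[nH]c4ccccc4c3C[C@@H]21`: 20 nM
- compound 2, `CN1[C@@H]2c3[nH]c4ccccc4c3C[C@H]1[C@H](C#N)N1[C@@H](CNC(=O)c3cccc4c3CCCC4)c3[nH]c4ccccc4c3C[C@@H]21`: 540 nM
- compound 3, `CN1[C@@H]2c3[nH]c4ccccc4c3C[C@H]1[C@H](C#N)N1[C@@H](CNC(=O)c3ccc4ccccc4n3)c3[nH]c4ccccc4c3C[C@@H]21`: 110 nM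

Compound 2 gives the highest of the three numbers in this assay; its nearest neighbour is compound 3, and compound 1 lies furthest from it. Among the compounds with values here, the one step recorded at the carbonyl carbon of the amide is a 4.9-fold lower number from compound 2 to compound 3 (0.69 log units; beyond the scatter), a modest change in the direction of a stronger inhibitor when the group on that carbon is exchanged. Within the data shown here, compound 1 carries a different arrangement at that position and no step to it is recorded; its value and that of compound 2 simply show the gap between the two.

Compound 4, `CN1[C@@H]2c3[nH]c4ccccc4c3C[C@H]1[C@H](C#N)N1[C@@H](CNC(=O)/C=C/c3cccc(C(F)(F)F)c3)c3[nH]c4ccccc4c3C[C@@H]21`, differs from compound 2 in the same region: 2-(3-(trifluoromethyl)phenyl)ethenyl in place of 1,2,3,4-tetrahydronaphthalen-5-yl on a carbonyl carbon. Among the measured compounds shown here, only the step from compound 2 to compound 3 bears on this change, and it shows that an exchange of the group on the carbonyl carbon can move the number downwards beyond the scatter. The entering group here is of a different kind from the quinolin-2-yl of compound 3, so the step is expected to be at most of similar size, and could fall within the scatter.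

The estimate for compound 4 in this assay is 250 nM, with a range of 80 nM to 800 nM, which amounts to an expected step of a 2.2-fold lower number from compound 2 to compound 4 (0.33 log units; beyond the scatter).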

Compound 4, half-maximal inhibitory concentration: 540 nM
Beside the measured number, compound 4's estimate is 2.2-fold (0.33 log units) below it, within the range that was stated.
By their numbers in this assay, from the lowest: compound 1; then compound 3; then compounds 2 and 4 (each within the scatter of the next).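

In this assay, exchanging the group on the carbonyl carbon does not by itself move the number: the record shows no change at the digits printed from compound 2 to compound 4 (within the scatter) even though 2-(3-(trifluoromethyl)phenyl)ethenyl differs from 1,2,3,4-tetrahydronaphthalen-5-yl in its heavy atoms, its rings and its double bond outside aromatic rings. Measured against quinolin-2-yl, the same entering group gives a 4.9-fold higher number from compound 3 to compound 4 (0.69 log units; beyond the scatter) and so matches the size of the earlier step in the opposite direction. Among these three amides, the lower number at this position therefore stays with quinolin-2-yl alone, the only one of the three groups with a ring nitrogen. Nothing available here accounts for these steps.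

The trifluoromethyl group and the double bond enter together, so their separate contributions remain unresolved, as does whether the ring nitrogen of quinolin-2-yl is what sets compound 3 apart. As far as these compounds go, it also remains open how an entering group bearing an amine or a carboxylic acid, or a longer chain on this carbonyl carbon, would read in this assay at this position.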